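Amino-bearing core compounds: methyl to hydrogen step

The source may hold more compounds than are shown below. What is called first, only, known or untested is meant among the compounds shown, and "the series" means these compounds.

Measured so far in a functional assay on the whole organism with Canis familiaris (Canis lupus familiaris) as the target, at a dose of 2 mg/kg by the intravenous route; a lower number here means a weaker effect, a higher number a stronger effect of the compound at the dose given:
- compound 1, `Cc1nc2c(OCc3ccccc3)ccc(C)n2c1C`: 13%
- compound 2, `Cc1cc(OCc2ccccc2)c2nc(C)c(C)n2c1`: 45%
- compound 3, `Cc1nc2c(OCc3ccccc3)cccn2c1N`: 97%

Compound 3 stands highest of the three numbers. Its nearest neighbour on the numbers is compound 2, whose value lies lower by a margin beyond the scatter, and the furthest is compound 1, lower still and also beyond the scatter. Among the measured compounds shown here, no step between two measured compounds that differ in one place is available, so the series gives no direct guide to the size of a single change.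

Compound 4, `Nc1cnc2c(OCc3ccccc3)cccn12`, is the next compound to be measured in this assay. It differs from compound 3 as follows: hydrogen in place of methyl on an aromatic carbon. The change removes one carbon from the five-membered aromatic ring of the shared core while the amino group and the benzyloxy group remain.

Since nothing in the measured set tests a methyl-to-hydrogen change, the expected step of a number 12 percentage points lower from compound 3 to compound 4 (beyond the scatter) is a small decrease, possibly within the scatter. On that basis compound 4 is estimated at 85%, within a range from 55% to 100%.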

Compound 4, a percentage reported as inhibition, in the whole organism at one dose (the size of the read-out at that dose, not a potency): 81%
Beside the measured number, compound 4's estimate is 4 percentage points above it; measured number inside the range.
By their numbers in this assay, from the lowest: compound 1; then compound 2; then compound 4; then compound 3.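

The series now has its first step between compounds that differ in one place: in this assay, hydrogen in place of methyl on an aromatic carbon of the five-membered aromatic ring gives a number 16 percentage points lower from compound 3 to compound 4 (beyond the scatter). This methyl is therefore not needed for a high read-out, as compound 4 still reaches 81%, yet its removal does change the read-out by more than the scatter. No measurement shown accounts for the size of this step.

Open, from the compounds shown here alone, is how an ethyl group, a longer chain or a carboxylic acid on this aromatic carbon would compare with methyl and hydrogen. Also open, going by these compounds, is how the step would look at another dose: the read-out is that of a single dose and not a potency.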